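Emax notes: aryl substituent change at the anisole-bearing nitrogen ring

This account rests on a few compounds, and the source may have more. Where it says the series, first, only, none or still open, it means among the compounds named here.

Measured so far in a functional assay on cells for agonist activity at Free fatty acid receptor 1 (Homo sapiens), read by FLIPR and calcium flux, with a stated time of 60 min; on this read-out lower numbers stand for smaller maximal responses and higher numbers for larger maximal responses:
- compound 1, `COc1ccc(CCCC(C)(C)C)c(N2CCC(COc3cccc(C(CC(=O)O)C4CC4)c3)CC2)c1`: 106%
- compound 2, `COc1ccc(C(C)C)c(N2CCC(COc3cccc(C(CC(=O)O)C4CC4)c3)CC2)c1`: 117%

For the measured compounds named here, compound 2 gives the higher of the two maximal responses, and the only measured step, a number 11 percentage points higher from compound 1 to compound 2 (beyond the scatter), places compound 1 below it. Both compounds reach or exceed the reference response.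

Compound 3, `COc1ccc(CCC(C)(C)O)c(N2CCC(COc3cccc(C(CC(=O)O)C4CC4)c3)CC2)c1`, is not yet measured in this assay. It differs from compound 2 as follows: 3-hydroxy-3-methylbutyl in place of isopropyl on an aromatic carbon. Going by the values given here, the one measured step concerns the same aromatic carbon, but there the change was between two alkyl groups without a hydroxyl; no measured pair shows a hydroxyl entering this position, so the step to compound 3 cannot be read off directly. Both measured compounds give a large maximal response, so compound 3 is expected to stay near that level, with the step of a number 7 percentage points lower from compound 2 to compound 3 (within the scatter) estimated to lie within the scatter. For compound 3 the expected value is 110%, with the range 90% to 128%.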

Compound 3, largest response reached (Emax), in percent of the reference or control that the assay uses: 109%
Compound 3: middle estimate off by 1 percentage points, on the high side, and the stated range covers the measured number.
By their numbers in this assay, from the lowest: compounds 1, 3 and 2 (each within the scatter of the next, the first and the last beyond it).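

In this assay, 3-hydroxy-3-methylbutyl on this aromatic carbon, para to a methoxy group, gives a number 8 percentage points lower from compound 2 to compound 3 (within the scatter) against isopropyl, and 1-hydroxy-1-methylethyl in place of neopentyl on the saturated chain carbon gives a number 3 percentage points higher from compound 1 to compound 3 (within the scatter) against the all-carbon chain. A chain carrying a hydrogen-bond donor and a hydrogen-bond acceptor therefore keeps the maximal response within the scatter of both alkyl compounds, which compound 1 and compound 2 alone could not show. For the compounds shown here, nothing measured so far explains this outcome.

On these data alone, whether the response holds with a primary amine or a carboxylic acid at the end of this chain stays open. Going by these compounds alone, the hydroxyl is also not separated from chain length, as no pair sets the 3-hydroxy-3-methylbutyl chain against an all-carbon chain of equal length.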